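A Methyl in Place of a Dimethylamino Group: Compound 4

This account rests on a few compounds, and the source may have more. Where it says the series, first, only, none or still open, it means among the compounds named here.

Measured compounds:
Compound 1, `COc1ccc(/C=C2\S/C(=N\c3csc(-c4ccc(Cl)cc4)c3)NC2=O)cc1OC` — in a functional assay on SW-620 cells (Homo sapiens) for cytotoxicity, read by MTT assay, with a stated time of 72 h (a lower number here means a stronger inhibitor, a higher number a weaker inhibitor), compound 1 reaches only the limit > 50000 nM.
Compound 2, `COc1cccc(N2C(=O)CS/C2=N\c2csc(-c3ccc(Cl)cc3)c2)c1` — in this assay compound 2 gives 33000 nM.
Compound 3, `CN(C)c1ccc(/C=C2\S/C(=N\c3nc(-c4ccc(Cl)cc4)cs3)NC2=O)cc1` — in this assay compound 3 gives 200 nM.

Compound 3 holds the lowest of the two numbers measured; the nearest number, that of compound 2, sits far beyond the scatter, and the value of compound 1 is a limit rather than a number (the limit of > 50000 nM in this assay, at which 1 of the 3 values shown sits). No pair among these three differs in only one place, so no measured step exists to lean on.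

Compound 4, `Cc1ccc(/C=C2\S/C(=N\c3nc(-c4ccc(Cl)cc4)cs3)NC2=O)cc1`, differs from compound 3 in a single place: methyl in place of dimethylamino on an aromatic carbon of a six-membered aromatic ring of carbon only, para to a large group. Going by the values given here, with no measured step of the same kind, the expectation rests on the change itself. The author expects the number to rise, by a step of a 13-fold higher number from compound 3 to compound 4 (1.10 log units; beyond the scatter) from compound 3 to compound 4, clearly beyond the scatter. For compound 4 in this assay the estimate is 2500 nM, with a range from 400 nM to 20000 nM.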

Compound 4, half-maximal inhibitory concentration: 890 nM
Compound 4: the middle estimate sits 2.8-fold (0.45 log units) above what was measured; low and high end bracket the measured number.
By their numbers in this assay, from the lowest: compound 3; then compound 4; then compound 2. At a limit, above all of these: compound 1.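

Going by these compounds alone, compound 3 and compound 4 form the first pair here that differs in one place only, so this position on the six-membered aromatic ring of carbon only, para to a large group, can now be read directly: in this assay, the change from 4-(dimethylamino)phenyl to 4-methylphenyl gives a 4.5-fold higher number from compound 3 to compound 4 (0.65 log units; beyond the scatter) and lies beyond the usual scatter. The dimethylamino group is therefore not indispensable for a measured value of this order, since compound 4, carrying only a methyl at that place, still gives 890 nM and the step stays modest. Nothing measured here explains why the number rises, and no reason for the step can be given from these data.

The compounds shown leave open whether the step follows the nitrogen of the dimethylamino group or simply the loss of its two carbons and nitrogen, a question that a primary amine, a methoxy group or an ethyl group at the same place would begin to separate. They also leave open whether a carboxylic acid or a longer alkyl chain at this position would be tolerated, and whether this single step would hold on the core of compound 2.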